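Aryl substituent series: saturated amine in place of pyrazolyl

This account rests on a few compounds, and the source may have more. Where it says the series, first, only, none or still open, it means among the compounds named here.

Among the compounds with values here, compound 2 `CCC(C)(C)Cc1c[nH]c(CCc2ccc(-n3cccn3)cc2)n1` gives 33 nM in an in vitro assay on CHO cells for displacement of a labelled ligand from Bombesin receptor subtype-3 (Homo sapiens), read by scintillation counting, with a stated time of 2 h (on this read-out lower numbers stand for stronger inhibition and higher numbers for weaker inhibition), the highest of the two numbers measured so far. Within the data shown here, its nearest neighbour is compound 1 `CCC(C)(C)Cc1c[nH]c(CCc2ccc(-c3cccc(C)n3)cc2)n1`, which in this assay gives 6.3 nM; the only step measured, a 5.2-fold higher number from compound 1 to compound 2 (0.72 log units; beyond the scatter), arose from 1H-pyrazol-1-yl in place of 6-methylpyridin-2-yl on an aromatic carbon.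

Compound 3 `CCC(C)(C)Cc1c[nH]c(CCc2ccc(N3CCCCC3)cc2)n1` is not yet measured. Relative to compound 2 it carries piperidin-1-yl in place of 1H-pyrazol-1-yl on an aromatic carbon. Among the measured compounds shown here, no measured step exchanges an aromatic substituent for a non-aromatic ring at this position, so the one available step, a 5.2-fold higher number from compound 1 to compound 2 (0.72 log units; beyond the scatter), bears on it only in showing that changes here move the number beyond the scatter. For compound 3 a further modest rise in this assay is expected, that is a 2.1-fold higher number from compound 2 to compound 3 (0.33 log units; beyond the scatter), with wide uncertainty. The estimate for compound 3 is 70 nM, ranging from 15 nM to 350 nM.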

Compound 3, half-maximal inhibitory concentration: 28 nM
Estimate against measurement, compound 3: 2.5-fold (0.40 log units) above; low and high end bracket the measured number.
By their numbers in this assay, from the lowest: compound 1; then compounds 3 and 2 (each within the scatter of the next).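

In this assay, the step to piperidin-1-yl, a 1.2-fold lower number from compound 2 to compound 3 (0.07 log units; within the scatter), shows that on this aromatic carbon a six-membered non-aromatic ring and a five-membered aromatic ring cannot be told apart, so an aromatic substituent is not required to stay at the level of compound 2. The step from 6-methylpyridin-2-yl, a 4.4-fold higher number from compound 1 to compound 3 (0.65 log units; beyond the scatter), sets compound 1 apart from compound 3 as well as from compound 2, so aromatic character alone does not sort these three compounds: compound 1 and compound 2 are both aromatic at this position, yet only compound 2 falls within the scatter of compound 3. Nothing available accounts for these results. Still open, from the compounds shown here alone, is whether the methyl group or the pyridine ring of 6-methylpyridin-2-yl carries the difference seen for compound 1. Also open, going by these compounds, is how an unmethylated pyridin-2-yl, a morpholin-4-yl or an open-chain dimethylamino group would read at this position.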